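Indole vinyl sulfones: acetyl to benzoyl step

A few compounds are considered here, and "the series" means these few. Any claim that something is new, unique, unknown or untested is made for them only; others in the source may bear on it.

Measured so far:
compound 1 `COc1ccc2[nH]c(-c3ccccc3)c(C=C(C#N)C#N)c2c1` — 865 nM
compound 2 `CC(=O)/C(=C\c1c(-c2ccccc2)[nH]c2ccccc12)S(=O)(=O)c1ccccc1` — "not determined" (no result reported)

In a functional assay on SR cells (Homo sapiens) for inhibition, read by sulforhodamine B assay, with a stated time of 48 h (on this read-out higher numbers stand for weaker inhibition of growth and lower numbers for stronger inhibition of growth), compound 1 gives 865 nM. For compound 2 this assay reports "not determined" (no result reported), so compound 2 stands on no number at all; the only measured point in the set is compound 1, whose core differs from that of compound 2 in both the substituent on the indole ring and the group on the exocyclic double bond, so it gives no direct reading on compound 2.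

Compound 3 `O=C(/C(=C\c1c(-c2ccccc2)[nH]c2ccccc12)S(=O)(=O)c1ccccc1)c1ccccc1` is to be measured. It differs from compound 2 in one place: phenyl in place of methyl on a carbonyl carbon. Among the measured compounds shown here, no step between measured compounds speaks to this change, so the size of its effect in this assay is not known; anything from none beyond the scatter to a moderate shift in either direction remains open. On the whole set, compound 3 is expected to come in at about 2000 nM, within 300 nM to 15000 nM.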

Compound 3, concentration for 50% growth inhibition: 9900 nM
Beside the measured number, compound 3's estimate is 5.0-fold (0.69 log units) below it; measured number inside the range.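

In this assay, among the compounds shown here, compound 3 gives 9900 nM but compound 2 has no number, so no step from acetyl to benzoyl can be read between them. On these data alone, the effect of phenyl in place of methyl on the carbonyl carbon stays open. No evidence at hand bears on this result.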